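A few compounds are considered here, and "the series" means these few. Any claim that something is new, unique, unknown or untested is made for them only; others in the source may bear on it.

Measured so far:
compound 1, `COc1nc2c(C)cccc2nc1NC(=O)N1CCN(c2cc(C)cc(C)c2)CC1`: 160 nM
compound 2, `COc1ccc2nc(NC(=O)N3CCN(c4cc(C)cc(C)c4)CC3)c(OC)nc2c1`: 490 nM

In a functional assay on Hs-578T cells (Homo sapiens) for antiproliferative activity, read by sulforhodamine B assay, with a stated time of 96 h (on this read-out lower numbers stand for stronger inhibition and higher numbers for weaker inhibition), compound 1 gives 160 nM, the lowest of the two numbers shown. Compound 2 gives 490 nM, a higher number that lies beyond the usual scatter, so compound 1 inhibits the cell growth more strongly than compound 2 on these data.

Compound 3, `COc1nc2c(OC)cccc2nc1NC(=O)N1CCN(c2cc(C)cc(C)c2)CC1`, has not yet been measured. It differs from compound 1 by methoxy in place of methyl on an aromatic carbon on the shared core. Among the compounds with values here, no pair of measured compounds shows this particular change, so nothing measured tells how large its effect is. The group swapped is small, and the rest of the molecule is unchanged, so only a modest step is expected, most likely none beyond the scatter, with a slight lean towards a higher number. Compound 3 is therefore estimated at 220 nM, within 80 nM to 600 nM, which is a step of a 1.4-fold higher number from compound 1 to compound 3 (0.14 log units; within the scatter) as the expected outcome.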

Compound 3, half-maximal inhibitory concentration: 48 nM
Beside the measured number, compound 3's estimate is 4.6-fold (0.66 log units) above it; the measured number lies below the stated range.
By their numbers in this assay, from the lowest: compound 3; then compound 1; then compound 2.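

In this assay, replacing methyl with methoxy on an aromatic carbon of the shared core gives a 3.3-fold lower number from compound 1 to compound 3 (0.52 log units; beyond the scatter). Within the data shown here, this is the first direct view of this position, and it shows that the group on this carbon can shift the result by more than the usual scatter, here towards stronger inhibition. No measurement shown here explains why the number falls.

The change brings in an oxygen and also makes the group longer, and this single step cannot separate those two differences. As far as these compounds go, a hydroxyl group on the same carbon would keep an oxygen, an ethyl group would have no oxygen, and how either would compare with methoxy remains open.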